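The compounds below may be only part of what the source reports. "The series", "measured", "known", "first", "only" and "open" are said of these compounds alone.

Compound 1 `NC(C(=O)O)c1cnn(O)c1Br`, compound 2 `CCCCc1c(C(N)C(=O)O)cnn1O`.

In a functional assay on CHO cells for agonist activity at metabotropic glutamate receptor 1 (Rattus norvegicus), read by calcium flux (on this read-out higher numbers stand for an effect only at larger amounts of compound and lower numbers for an effect already at smaller amounts), compound 1 gives > 1000000 nM, which is a limit of the assay and not a number. In this assay compound 2 likewise gives only a limit, > 1000000 nM. The change from compound 1 to compound 2, butyl in place of bromo on an aromatic carbon, is therefore a step whose size cannot be read, a step that the two limits leave unreadable from compound 1 to compound 2, because both values sit at the limit of > 1000000 nM in this assay, at which 2 of the 2 values shown sit. Compound 2 thus stands at the limit with no number of its own.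

Compound 3 `CCCCCc1c(C(N)C(=O)O)cnn1O` differs from compound 2 by methyl in place of hydrogen on a saturated chain carbon, four bonds along the chain from an aromatic carbon. Going by the values given here, no measured step of this kind exists, and the single measured step is unreadable, so no direction beyond the scatter can be expected: the expected step is a number no higher from compound 2 to compound 3 (the limit leaves the size open). Compound 3 is accordingly estimated at 1000000 nM, with a range from 300000 nM to 3000000 nM, most likely again only a limit.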

Compound 3, half-maximal effective concentration: > 1000000 nM
Compound 3 gave a limit, no number; the forecaster's own chance of this, stated with the estimate: 85%; the middle value sits exactly at the limit.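

None of the steps among compound 1, compound 2 and compound 3 can be read, because each of the three compounds gives only a limit and not a number: the limit of > 1000000 nM in this assay, at which 3 of the 3 values shown sit.

The compounds shown leave open whether bromo, butyl and pentyl differ at all in this assay.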